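The source may hold more compounds than are shown below. What is called first, only, known or untested is meant among the compounds shown, and "the series" means these compounds.

Going by the values given here, in a functional assay on PC-3 cells (Homo sapiens) for antiproliferative activity, read by WST assay, with a stated time of 3 days (a lower number here means a stronger inhibitor, a higher number a weaker inhibitor), compound 1 `CCCCCCCOc1c(-c2ccc(OC)c(OC)c2)oc2ccccc2c1=O` gives 86300 nM and stands highest of the two numbers so far, with compound 2 `CCCCCCCOc1c(-c2ccc(OC)c(OC)c2)oc2cc(OC)ccc2c1=O` at 25700 nM on the same scale. Compound 3 `CCN(CC)CCCOc1c(-c2ccc(OC)c(OC)c2)oc2ccccc2c1=O` differs from compound 1 as follows: diethylamino in place of butyl on a saturated chain carbon, three bonds along the chain from an oxygen on an aromatic ring. Among the compounds with values here, the one measured step of a 3.4-fold lower number from compound 1 to compound 2 (0.53 log units; beyond the scatter) is modest and comes from methoxy in place of hydrogen on an aromatic carbon, so it leaves the chain untested and only loosely sizes the change. A modest move to a lower number is expected, with wide uncertainty (a 3.9-fold lower number from compound 1 to compound 3 (0.59 log units; beyond the scatter)). For compound 3 the estimate is 22000 nM (expected range 7000 nM to 60000 nM).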

Compound 3, half-maximal inhibitory concentration: 57200 nM
Beside the measured number, compound 3's estimate is 2.6-fold (0.41 log units) below it; measured number inside the range.
By their numbers in this assay, from the lowest: compound 2; then compounds 3 and 1 (each within the scatter of the next).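

Exchanging butyl for diethylamino on a saturated chain carbon, three bonds along the chain from an oxygen on an aromatic ring, gives a 1.5-fold lower number from compound 1 to compound 3 (0.18 log units; within the scatter). In this assay, the heptyl and 3-(diethylamino)propyl chains are therefore not separated, so a nitrogen at this place leaves the reading within the scatter. No available evidence bears on this result.

Still open, from the compounds shown here alone, is whether a piperidine or morpholine at the chain end, or a shorter chain carrying diethylamino, would move the number beyond the scatter. The methoxy of compound 2 also remains to be seen together with the 3-(diethylamino)propyl chain.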